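Working notes: methoxy in place of chloro on compound 2

The source may report more compounds than this note shows. Statements on the series, on what has been measured and on what is new or still open speak of the compounds shown alone.

- compound 1 `COc1ccc(-c2nc(C)c(C(=O)CSc3nc(-c4ccc(OC)cc4)c(C#N)c(=O)[nH]3)s2)cc1` gives 25300 nM in a functional assay on U-87MG ATCC cells for antiproliferative activity against U-87 MG (Homo sapiens), read by MTT assay, with a stated time of 48 h; on this read-out lower numbers stand for stronger inhibition and higher numbers for weaker inhibition
- compound 2 `Cc1nc(-c2ccc(Cl)cc2)sc1C(=O)CSc1nc(-c2ccc(Cl)c(Cl)c2)c(C#N)c(=O)[nH]1` gives 83900 nM in this assay

Compound 2 holds the higher of the two numbers in this assay and is the weaker of the pair, with its gap to compound 1 beyond the scatter. The next compound is compound 3 `COc1ccc(-c2nc(C)c(C(=O)CSc3nc(-c4ccc(Cl)c(Cl)c4)c(C#N)c(=O)[nH]3)s2)cc1` and it differs from compound 2 in one place, with methoxy in place of chloro on an aromatic carbon, para to a large group (methoxy in place of chloro on an aromatic carbon). Among the compounds with values here, no measured pair shows this change alone. Within the data shown here, the only lower number is that of compound 1 at 25300 nM and the expectation rests on it. An estimated step of a 1.9-fold lower number from compound 2 to compound 3 (0.27 log units; within the scatter) is expected in this assay toward a lower number, about the size of the scatter. For compound 3 the expected value is 45000 nM with an estimated range from 20000 nM to 100000 nM for repeated measurements.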

Compound 3, half-maximal inhibitory concentration: 68500 nM
The estimate for compound 3 lay 1.5-fold (0.18 log units) below the measured number, within the range that was stated.
By their numbers in this assay, from the lowest: compound 1; then compounds 3 and 2 (each within the scatter of the next).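

In this assay, 4-methoxyphenyl in place of 4-chlorophenyl gives a 1.2-fold lower number from compound 2 to compound 3 (0.09 log units; within the scatter) with the 3,4-dichlorophenyl group kept, so this exchange of chloro for methoxy at this position does not separate the two compounds. The change that does register lies at the other aryl group: 3,4-dichlorophenyl in place of 4-methoxyphenyl gives a 2.7-fold higher number from compound 1 to compound 3 (0.43 log units; beyond the scatter) in this assay, a modest step and the only one of the two beyond the scatter. No measurement here bears on the reason for either step.

Going by these compounds, the exchange of chloro for methoxy is read against a single partner group, so its behaviour with any other group at the far aryl position remains open. Also open, on these data alone, is whether an amine or a carboxylic acid on this aromatic carbon would give a step beyond the scatter.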